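The source may hold more compounds than are shown below. What is called first, only, known or untested is meant among the compounds shown, and "the series" means these compounds.

Compounds measured in a functional assay on HepG2 cells (Homo sapiens) for antiproliferative activity, read by MTT assay, with a stated time of 48 h; a lower number here means a stronger inhibitor of growth, a higher number a weaker inhibitor of growth:
compound 1 `CCCCN(Cc1ccc(C(=O)NO)cc1)c1ncc(-c2ccc(C)cc2)s1`, 4300 nM
compound 2 `Cc1ccc(OCCCN(Cc2ccc(C(=O)NO)cc2)c2ncc(-c3ccc(C)cc3)s2)cc1`, 12200 nM
compound 3 `Cc1ccc(-c2cnc(N(CCCCOc3ccccc3)Cc3ccc(C(=O)NO)cc3)s2)cc1`, 16600 nM

Compound 3 has the highest number of the three: one step is a 1.4-fold higher number from compound 2 to compound 3 (0.13 log units; within the scatter), the other is a 3.9-fold higher number from compound 1 to compound 3 (0.59 log units; beyond the scatter). Compound 4 `CCCCCCCCN(Cc1ccc(C(=O)NO)cc1)c1ncc(-c2ccc(C)cc2)s1` differs from compound 3 by butyl in place of phenoxy on a saturated chain carbon, four bonds along the chain from a nitrogen on an aromatic ring. The step that bears on this is a 3.9-fold higher number from compound 1 to compound 3 (0.59 log units; beyond the scatter), where a phenoxy at this place raised the number; its removal is expected to lower it again. Among the compounds with values here, whether a butyl at the same place hands back the full difference has no measured counterpart, and a 2.8-fold higher number from compound 1 to compound 2 (0.45 log units; beyond the scatter) shows a further case where a longer chain with an aromatic group raised the number. Compound 4 is therefore expected at 7000 nM, range 3000 nM to 18000 nM, a step of a 2.4-fold lower number from compound 3 to compound 4 (0.38 log units; beyond the scatter) in this assay.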

Compound 4, concentration for 50% growth inhibition: 8760 nM
Compound 4: middle estimate off by 1.3-fold (0.10 log units), on the low side, and the stated range covers the measured number.
By their numbers in this assay, from the lowest: compound 1; then compounds 4, 2 and 3 (each within the scatter of the next).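

In this assay, butyl in place of phenoxy on the chain does not separate compound 4 from the compounds carrying an aromatic ring on the chain (a 1.9-fold lower number from compound 3 to compound 4 (0.28 log units; within the scatter); a 1.4-fold lower number from compound 2 to compound 4 (0.14 log units; within the scatter)). Butyl in place of hydrogen at the same place still gives a step beyond the scatter (a 2.0-fold higher number from compound 1 to compound 4 (0.31 log units; beyond the scatter)), so among these compounds a higher number than that of compound 1 does not require a phenoxy group. No measured evidence accounts for these steps.

Still open, as far as these compounds go, is how an amine or a carboxylic acid at the end of this chain would compare with compound 4, and whether a chain shorter than that of compound 1 would give a lower number.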